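From cyclopropylmethoxy to ethylsulfanyl

The source may hold more compounds than are shown below. What is called first, only, known or untested is meant among the compounds shown, and "the series" means these compounds.

Compound 1 `CCSc1ccccc1-c1ncc(C(=O)O)c(=O)[nH]1`: 25 mg/kg
Compound 2 `CCOC(=O)c1cnc(-c2ccccc2O)[nH]c1=O`: 5 mg/kg
Compound 3 `CCOC(=O)c1cnc(-c2ccccc2OCC2CC2)[nH]c1=O`: 0.3 mg/kg

In a functional assay on the whole organism (strain Sprague-Dawley) for inhibition, with Rattus norvegicus as the target, with a stated time of 10 min (a lower number here means that less compound is needed, a higher number that more compound is needed for the effect), compound 3 gives 0.3 mg/kg, the lowest of the three numbers. The next structure, compound 4 `CCOC(=O)c1cnc(-c2ccccc2SCC)[nH]c1=O`, changes one group: ethylsulfanyl in place of cyclopropylmethoxy on an aromatic carbon. Among the measured compounds shown here, one measured step bears on this place, a 17-fold lower number from compound 2 to compound 3 (1.22 log units; beyond the scatter), and it is large, so the group at this position can matter a great deal. Compound 1 carries ethylsulfanyl but differs elsewhere too, and it gives 25 mg/kg, which makes it only a loose guide. Weighing these two, a moderate move toward a higher number is expected in this assay. The expected step is a 3.3-fold higher number from compound 3 to compound 4 (0.52 log units; beyond the scatter). For compound 4 the estimated value is 1 mg/kg, with an expected range of 0.25 mg/kg to 5 mg/kg.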

Compound 4, dose for 50% inhibition: > 5 mg/kg
Compound 4: no number, only a limit; the forecaster's own chance of this, stated with the estimate: 3%; at least 5.0-fold (0.69 log units) between middle value and limit.
By their numbers in this assay, from the lowest: compound 3; then compound 2; then compound 1.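

Compound 4 gives a limit rather than a number: the limit of > 5 mg/kg in this assay, at which 1 of the 4 values shown sits.

Even so, ethylsulfanyl in place of cyclopropylmethoxy gives an at least 16-fold higher number from compound 3 to compound 4 (1.22 log units; beyond the scatter). The low number of compound 3 therefore does not carry over to this smaller, ring-free group on the same aromatic carbon, although both groups count one hydrogen-bond acceptor. Ethylsulfanyl in place of hydroxy gives a number no lower from compound 2 to compound 4 (the limit leaves the size open). The step to compound 4 from compound 1 cannot be read.

The change swaps oxygen for sulfur and also removes the three-membered ring, so the compounds shown cannot separate the two. An ethoxy group or a cyclopropylmethylsulfanyl group would pull them apart.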